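Swapping the Sulfonamide Substituent in a Urea Activator Series

The source may report more compounds than this note shows. Statements on the series, on what has been measured and on what is new or still open speak of the compounds shown alone.

Of the compounds shown here, two have been tested in an assay on isolated protein for activation of Nicotinamide phosphoribosyltransferase (Homo sapiens); on this read-out higher numbers stand for an effect only at larger amounts of compound and lower numbers for an effect already at smaller amounts. Compound 1 `CCOC(=O)c1ccc(NC(=O)NCc2cocn2)cc1` gives 27600 nM. Compound 2 `CCN(C1CCCC1)S(=O)(=O)c1ccc(NC(=O)NCc2ccncc2)cc1`, which carries a sulfonyl group on its aromatic ring, gives 60 nM and so stands as the stronger of the two by a margin well beyond the usual scatter. Compound 3 `O=C(NCc1ccncc1)Nc1ccc(S(=O)(=O)N2CCc3ccccc3C2)cc1` keeps the whole framework of compound 2 and differs in a single spot: 1,2,3,4-tetrahydroisoquinolin-2-yl in place of cyclopentyl(ethyl)amino on a sulfonyl sulfur. For the measured compounds named here, no measured pair shows what such a swap does in this assay, so the size of the step is open. Both the leaving and the entering group sit on the sulfonyl sulfur and each contains one nitrogen, so in this assay no change beyond the scatter is expected from compound 2 to compound 3 (a 1.3-fold higher number from compound 2 to compound 3 (0.12 log units; within the scatter)). Compound 3 is therefore estimated at 80 nM, within a range of 20 nM to 320 nM.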

Compound 3, half-maximal effective concentration: 142 nM
The estimate for compound 3 lay 1.8-fold (0.25 log units) below the measured number, and the stated range covers the measured number.
By their numbers in this assay, from the lowest: compound 2; then compound 3; then compound 1.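

In this assay, for the compounds shown here, the step from the cyclopentyl(ethyl)amino group to the 1,2,3,4-tetrahydroisoquinolin-2-yl group is the first change in one place that can be read, and it gives a 2.4-fold higher number from compound 2 to compound 3 (0.37 log units; beyond the scatter) as a modest loss that still lies beyond the usual scatter. The sulfonyl sulfur therefore accepts a group with a six-membered aromatic ring, and compound 3 still gives 142 nM in this assay. Nothing available explains why the number rises.

This single swap cannot separate the contribution of the aromatic ring from that of the six-membered non-aromatic ring that holds the nitrogen. Going by these compounds, how a piperidine, a morpholine or a simple dimethylamino group on the sulfonyl sulfur would behave also remains open.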